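Acylguanidine series: imidazolyl in place of chlorophenoxy

The source may report more compounds than this note shows. Statements on the series, on what has been measured and on what is new or still open speak of the compounds shown alone.

In a functional assay for inhibition of sodium/hydrogen exchanger (Oryctolagus cuniculus) (on this read-out higher numbers stand for weaker inhibition and lower numbers for stronger inhibition), compound 2 `Cc1cc(Oc2cccc(Cl)c2)c(S(C)(=O)=O)cc1C(=O)N=C(N)N` gives 21 nM; compound 1 `Cc1cc(Sc2ccc(Cl)cc2)c(S(C)(=O)=O)cc1C(=O)N=C(N)N` gives 19 nM, and the step of a 1.1-fold higher number from compound 1 to compound 2 (0.04 log units; within the scatter) leaves the two within the scatter. Compound 3 `Cc1cc(-n2ccnc2C)c(S(C)(=O)=O)cc1C(=O)N=C(N)N` carries 2-methyl-1H-imidazol-1-yl in place of 3-chlorophenoxy on an aromatic carbon. For the measured compounds named here, only that one step touches this position, and it kept a chlorinated six-membered ring; no measured step shows a five-membered ring with two hetero atoms here, so the expectation is weakly founded. A modest rise in this assay is expected, a 2.1-fold higher number from compound 2 to compound 3 (0.33 log units; beyond the scatter), since the change goes beyond what compound 1 and compound 2 sample. Compound 3 is estimated at 45 nM, within 10 nM to 200 nM.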

Compound 3, half-maximal inhibitory concentration: 29 nM
Compound 3: the middle estimate sits 1.6-fold (0.19 log units) above what was measured, within the range that was stated.
By their numbers in this assay, from the lowest: compounds 1, 2 and 3 (each within the scatter of the next).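

In this assay, the place ortho to the methylsulfonyl group accepts a five-membered aromatic ring with 2 hetero atoms: 2-methyl-1H-imidazol-1-yl gives a 1.4-fold higher number from compound 2 to compound 3 (0.14 log units; within the scatter) and a 1.5-fold higher number from compound 1 to compound 3 (0.18 log units; within the scatter). Within these compounds, then, neither a chlorine nor a six-membered ring of carbon only is needed at this place to stay within the scatter. Nothing available bears on why these groups read alike.

From the compounds shown here alone, whether unmethylated imidazol-1-yl, a dimethylamino group or a carboxylic acid would also read alike at this place remains open.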